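Nitro to amino on the anilino ring of compound 2

This account rests on a few compounds, and the source may have more. Where it says the series, first, only, none or still open, it means among the compounds named here.

Going by the values given here, compound 2 `CNc1nc(Nc2ccc(C)c([N+](=O)[O-])c2)ncc1C(=O)Nc1cc(NC(=O)c2ccc(OC)cc2)ccc1C` is the weaker of the two measured compounds in a functional assay on K562 cells (Homo sapiens) for antiproliferative activity, read by CellTiter-Glo and CCK-8 assay, with a stated time of 72 h (a higher number here means a weaker inhibitor of growth, a lower number a stronger inhibitor of growth), giving 1530 nM, while compound 1 `CNc1nc(Nc2ccc(C)c([N+](=O)[O-])c2)ncc1C(=O)Nc1cc(NC(=O)c2cccc(OC)c2)ccc1C` gives 480 nM; the one measured step, a 3.2-fold higher number from compound 1 to compound 2 (0.50 log units; beyond the scatter), concerns the methoxy position alone. Among the compounds with values here, compound 3 `CNc1nc(Nc2ccc(C)c(N)c2)ncc1C(=O)Nc1cc(NC(=O)c2ccc(OC)cc2)ccc1C` differs from compound 2 by amino in place of nitro on an aromatic carbon, a change no measured step covers, so nothing here says in which direction it should move. On that basis the expected step is a 1.0-fold lower number from compound 2 to compound 3 (0.01 log units; within the scatter), with compound 3 estimated at 1500 nM and a wide range from 400 nM to 6000 nM.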

Compound 3, concentration for 50% growth inhibition: 610 nM
Compound 3: middle estimate off by 2.5-fold (0.39 log units), on the high side; the measured number falls inside the stated range.
By their numbers in this assay, from the lowest: compounds 1 and 3 (each within the scatter of the next); then compound 2.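

Replacing the nitro of the 4-methyl-3-nitrophenyl group with amino gives a 2.5-fold lower number from compound 2 to compound 3 (0.40 log units; beyond the scatter) in this assay. Going by these compounds alone, this is the first measured change on this ring, and it shows that the position responds to substitution and that nitro is not required for growth inhibition here. Nothing available explains this step.

On these data alone, whether amino brings a similar step alongside the 3-methoxyphenyl of compound 1 remains open. So does how a hydroxyl, an acetamide or a dimethylamino group would read at this position.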